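The compounds below may be only part of what the source reports. "The series", "measured", "known", "first", "only" and "open" are said of these compounds alone.

Measured compounds in a functional assay on NCI-H2122 cells (Homo sapiens) for inhibition, read by microscopy, with a stated time of 10 days; a lower number here means a stronger inhibitor, a higher number a weaker inhibitor:
compound 1, `COc1ccc(C2C(C#N)=C(N)Oc3c2c(-c2ccccc2)nn3C)cc1`: compound 1 gives > 10000 nM, a limit of the assay
compound 2, `Cn1nc(-c2ccccc2)c2c1OC(N)=C(C#N)C2c1ccc(C(F)(F)F)cc1`: compound 2 gives 4100 nM

Going by the values given here, compound 2 holds the only numerical value in this assay; the other value shown is a limit, noted as the limit of > 10000 nM in this assay, at which 1 of the 2 values shown sits. Among the compounds with values here, the one measured step, an at least 2.4-fold lower number from compound 1 to compound 2 (0.38 log units; beyond the scatter), came with trifluoromethyl in place of methoxy on an aromatic carbon.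

Compound 3, `Cn1nc(-c2ccccc2)c2c1OC(N)=C(C#N)C2c1ccc(OC(F)(F)F)cc1`, is not yet measured. It differs from compound 2 by trifluoromethoxy in place of trifluoromethyl on an aromatic carbon, on an aromatic carbon of a six-membered aromatic ring of carbon only, para to a large group. The measured step bears on the same position, but it compared methoxy with trifluoromethyl; neither compound carries trifluoromethoxy, so the expected size is uncertain. A step in this assay of no more than the usual scatter is expected from compound 2 to compound 3, a 1.0-fold lower number from compound 2 to compound 3 (0.01 log units; within the scatter). Compound 3 is estimated at 4000 nM, within 1500 nM to 12000 nM.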

Compound 3, half-maximal inhibitory concentration: 5500 nM
For compound 3 the middle estimate is 1.4-fold (0.14 log units) below the measured one, within the range that was stated.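

At this position, para to a large group, the exchange of trifluoromethyl for trifluoromethoxy makes no clear difference in this assay: the result is a 1.3-fold higher number from compound 2 to compound 3 (0.13 log units; within the scatter). The other new comparison is an at least 1.8-fold lower number from compound 1 to compound 3 (0.25 log units; that floor lies within the scatter), and with its floor inside the scatter, it does not establish that trifluoromethoxy is better than methoxy here, even though the trifluoromethyl step from methoxy went beyond the scatter. Compound 1 is held at a limit and not a number: the limit of > 10000 nM in this assay, at which 1 of the 3 values shown sits.

Still open, on these data alone, is how an amine, a carboxylic acid or a longer alkoxy chain at this position would read in this assay. Also open, as far as these compounds go, is whether these small steps would hold with other substituents on the shared core.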